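Aryl in place of alkynyl on the core: compound 4

The compounds below may be only part of what the source reports. "The series", "measured", "known", "first", "only" and "open" are said of these compounds alone.

Compound 1 `CCCCC#Cc1cc([C@@H]2O[C@H](CO)[C@@H](O)[C@H]2O)n2ncnc(N)c12` carries a hex-1-yn-1-yl group on the shared core and gives 2900 nM in a functional assay on HCT-116 cells (Homo sapiens) for antiproliferative activity, with a stated time of 72 h; on this read-out higher numbers stand for weaker inhibition and lower numbers for stronger inhibition. Of the numbers measured it sits lowest; the nearest is compound 2 `Nc1ncnn2c([C@@H]3O[C@H](CO)[C@@H](O)[C@H]3O)cc(-c3ccc(F)cc3)c12`, which gives 42500 nM, a step of a 15-fold higher number from compound 1 to compound 2 (1.17 log units; beyond the scatter). Compound 3 `Nc1ncnn2c([C@@H]3O[C@H](CO)[C@@H](O)[C@H]3O)cc(-c3ccccc3F)c12` reaches only a limit of this assay, > 100000 nM, namely (the limit of > 100000 nM in this assay, at which 1 of the 3 values shown sits). That step is an at least 34-fold higher number from compound 1 to compound 3 (1.53 log units; beyond the scatter). Between the two aryl compounds the step is an at least 2.3-fold higher number from compound 2 to compound 3 (0.37 log units; beyond the scatter).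

Compound 4 `COc1ccc(-c2cc([C@@H]3O[C@H](CO)[C@@H](O)[C@H]3O)n3ncnc(N)c23)cc1` differs from compound 1 in 4-methoxyphenyl in place of hex-1-yn-1-yl on an aromatic carbon. Both measured replacements of hex-1-yn-1-yl by an aryl group on this carbon raised the number by a large margin, so a large rise is expected here as well. The 4-methoxyphenyl case, substituted in the same ring position as the 4-fluorophenyl of compound 2, is taken to lie close to the value of compound 2, 42500 nM. It is not expected to reach the limit seen for compound 3. The step expected is a 14-fold higher number from compound 1 to compound 4 (1.14 log units; beyond the scatter). Compound 4 is estimated at 40000 nM, with a range from 10000 nM to 150000 nM; a limit-only result cannot be excluded.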

Compound 4, half-maximal inhibitory concentration: 47100 nM
Compound 4: the middle estimate sits 1.2-fold (0.07 log units) below what was measured, within the range that was stated.
By their numbers in this assay, from the lowest: compound 1; then compounds 2 and 4 (each within the scatter of the next). At a limit, above all of these: compound 3.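

With 4-methoxyphenyl, the loss on leaving hex-1-yn-1-yl holds for a third aryl group, a 16-fold higher number from compound 1 to compound 4 (1.21 log units; beyond the scatter), while methoxy in place of fluoro changes nothing that can be read, a 1.1-fold higher number from compound 2 to compound 4 (0.04 log units; within the scatter), so the 4-fluorophenyl and 4-methoxyphenyl groups cannot be told apart at this carbon. Among the aryl groups, the one difference beyond the scatter so far concerns 2-fluorophenyl, with an at least 2.1-fold lower number from compound 3 to compound 4 (0.32 log units; beyond the scatter) agreeing with the earlier comparison against 4-fluorophenyl. Compound 3 stands at a limit, so this step has only a lower bound: the limit of > 100000 nM in this assay, at which 1 of the 4 values shown sits.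

As far as these compounds go, whether a longer or shorter alkynyl chain than hex-1-yn-1-yl gives a lower number than compound 1 remains open. Also open, from the compounds shown here alone, is whether a phenyl ring carrying an amine or a carboxylic acid in place of fluoro or methoxy would depart from compound 2 and compound 4.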